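Swapping Cyclohexyl for Piperidinyl on a Sulfonyl Group

The compounds below may be only part of what the source reports. "The series", "measured", "known", "first", "only" and "open" are said of these compounds alone.

Compound 1, `O=S(=O)(C1CCCCC1)N1CCc2nc(C#Cc3ccccc3)sc2C1`, gives > 10000 nM in an assay on HEK293 cells for positive allosteric modulation of metabotropic glutamate receptor 5 (Homo sapiens), read by FLIPR, with a stated time of 1 h; a higher number here means that more compound is needed for the effect, a lower number that less compound is needed.
Compound 2, `O=S(=O)(C1CCCCC1)N1Cc2nc(C#Cc3ccccc3)sc2C1`, gives 150 nM in this assay.
Compound 3, `O=S(=O)(N1CCCCC1)N1CCc2nc(C#Cc3ccccc3)sc2C1`, gives > 10000 nM in this assay.

The value for compound 1 is a limit of the assay and not a number. The value for compound 3 is likewise a limit. Compound 2 is the only one of the three that gives a number in this assay. Compound 1 and compound 2 differ in their cores, and the difference between the two cores is not broken down here.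

Compound 3 arises from compound 1 by the change (piperidin-1-yl in place of cyclohexyl on a sulfonyl sulfur). As far as these compounds go, the step that the two limits leave unreadable from compound 1 to compound 3 cannot be read because of the limit of > 10000 nM in this assay, at which 2 of the 3 values shown sit: both values sit at the same limit, so the size of the step is unknown.

Compound 4, `O=S(=O)(N1CCCCC1)N1Cc2nc(C#Cc3ccccc3)sc2C1`, has not yet been measured in this assay. It arises from compound 2 by the same change, (piperidin-1-yl in place of cyclohexyl on a sulfonyl sulfur). Among the compounds with values here, the one earlier example of this change, from compound 1 to compound 3, gives no readable size, so the expectation for compound 4 rests on compound 2 alone, whose value of 150 nM is the only number in the set.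

The step from compound 2 to compound 4 is expected to be a modest loss, a 2.7-fold higher number from compound 2 to compound 4 (0.43 log units; beyond the scatter), with wide uncertainty. Compound 4 is estimated at 400 nM, with a likely range from 100 nM to 3000 nM.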

Compound 4, half-maximal effective concentration: 250 nM
Compound 4: the middle estimate sits 1.6-fold (0.20 log units) above what was measured, within the range that was stated.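

In this assay, placing piperidin-1-yl where cyclohexyl stood on the sulfonyl sulfur gives a 1.7-fold higher number from compound 2 to compound 4 (0.22 log units; within the scatter), so on the core of compound 2 the two groups cannot be told apart by this measurement. Whether the same holds on the core of compound 1 cannot be said, because the step from compound 1 to compound 3 cannot be read, and both values there are limits of the assay rather than numbers: the limit of > 10000 nM in this assay, at which 2 of the 4 values shown sit. The set therefore holds a single readable example of this change, on a single core, which shows that the swap can be made there without a step beyond the scatter but does not show that the result carries from one core to another.

The compounds shown leave open how other groups would behave in this place on the core of compound 2, such as morpholin-4-yl, piperazin-1-yl or an open-chain dimethylamino group. They also leave open whether a hydroxyl group or a fluorine atom added to the piperidin-1-yl ring would leave the number within the scatter of the value for compound 4.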